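This account rests on a few compounds, and the source may have more. Where it says the series, first, only, none or still open, it means among the compounds named here.

Three closely related compounds have been measured in a functional assay on A549 cells (Homo sapiens) for antiproliferative activity, read by MTT assay, with a stated time of 24 h; a higher number here means a weaker inhibitor, a lower number a stronger inhibitor: compound 1 `Cc1ccc(-c2nn(-c3ccccc3)cc2-c2nc3ccccc3n2S(=O)(=O)c2ccc(C(F)(F)F)cc2)cc1` gives 1460 nM, compound 2 `COc1ccc(S(=O)(=O)n2c(-c3cn(-c4ccccc4)nc3-c3ccc(F)cc3)nc3ccccc32)cc1` gives 350 nM and compound 3 `O=[N+]([O-])c1ccc(S(=O)(=O)n2c(-c3cn(-c4ccccc4)nc3-c3ccc(F)cc3)nc3ccccc32)cc1` gives 1030 nM. Going by the values given here, the number for compound 3 lies within the scatter of the one for compound 1, while compound 2 stands apart from compound 3 with a clearly lower number, which marks a stronger inhibitor.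

The next compound, compound 4 `O=S(=O)(c1ccc(C(F)(F)F)cc1)n1c(-c2cn(-c3ccccc3)nc2-c2ccc(F)cc2)nc2ccccc21`, differs from compound 3 in a single place: trifluoromethyl in place of nitro on an aromatic carbon. In words, trifluoromethyl takes the place of nitro on an aromatic carbon, para to a large group. Among the compounds with values here, the only measured step at this place is a 2.9-fold higher number from compound 2 to compound 3 (0.47 log units; beyond the scatter), a modest change beyond the scatter, with nitro in place of methoxy. That step shows that this place can move the number, but it says nothing directly about trifluoromethyl. Compound 1 does carry the 4-(trifluoromethyl)phenyl group, and it gives 1460 nM, though it also differs from compound 4 elsewhere. Within the data shown here, that value is within the scatter of the one for compound 3, so no change beyond the scatter is expected, and the estimated step is a 1.0-fold lower number from compound 3 to compound 4 (0.01 log units; within the scatter). The expected value for compound 4 is 1000 nM, with an estimated range of 450 nM to 2200 nM.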

Compound 4, half-maximal inhibitory concentration: 1280 nM
Compound 4: the middle estimate sits 1.3-fold (0.11 log units) below what was measured; the range from low to high includes it.
By their numbers in this assay, from the lowest: compound 2; then compounds 3, 4 and 1 (each within the scatter of the next).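

In this assay, trifluoromethyl and nitro cannot be told apart at this place on the ring, para to a large group (a 1.2-fold higher number from compound 3 to compound 4 (0.09 log units; within the scatter)). Methoxy now stands apart from a second group there and not from nitro alone (a 3.7-fold higher number from compound 2 to compound 4 (0.56 log units; beyond the scatter)), so among the three groups shown, only methoxy goes with a clearly lower number, which marks a stronger inhibitor. The fluoro and methyl pair, which carries trifluoromethyl at this place in both compounds, adds that fluoro in place of methyl on an aromatic carbon gives a step inside the usual scatter (a 1.1-fold lower number from compound 1 to compound 4 (0.06 log units; within the scatter)), and no measurement here explains any of these steps.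

The compounds shown carry only methoxy, nitro and trifluoromethyl at this place, so it stays open how an amine, a carboxylic acid or a longer chain such as ethoxy would read there. It also stays open whether the gap seen with methoxy would hold in a compound with methyl in place of fluoro, as methoxy is shown here only together with fluoro.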